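Replacing the Aryl Group at the Quaternary Carbon

The compounds below may be only part of what the source reports. "The series", "measured", "known", "first", "only" and "open" are said of these compounds alone.

Measured compounds:
- compound 1 `Cc1ccc(C2(c3ccc(O)cc3)C(=O)Nc3c2ccc(F)c3F)cc1`, 1.7 nM
- compound 2 `O=C1Nc2c(ccc(F)c2F)C1(c1ccc(O)cc1)C1CCCC1`, 12 nM

In a functional assay on MCF7 cells (Homo sapiens) for cytotoxicity, read by WST assay, with a stated time of 72 h (on this read-out higher numbers stand for weaker inhibition and lower numbers for stronger inhibition), compound 1 gives the lowest of the two numbers shown, with compound 2 nearest to it at 12 nM. Compound 3 `O=C1Nc2c(ccc(F)c2F)C1(CC1CCCCC1)c1ccc(O)cc1` differs from compound 1 by cyclohexylmethyl in place of 4-methylphenyl on a saturated ring carbon. Among the compounds with values here, the only step that bears on this change is a 7.1-fold higher number from compound 1 to compound 2 (0.85 log units; beyond the scatter), where a saturated ring likewise replaced the 4-methylphenyl. A step of similar size in the same direction is therefore expected, an 8.8-fold higher number from compound 1 to compound 3 (0.95 log units; beyond the scatter). Compound 3 is estimated at 15 nM, with a range from 4 nM to 60 nM.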

Compound 3, half-maximal inhibitory concentration: 102 nM
Beside the measured number, compound 3's estimate is 6.8-fold (0.83 log units) below it, outside the stated range (above it).
By their numbers in this assay, from the lowest: compound 1; then compound 2; then compound 3.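

Although 4-methylphenyl and cyclohexylmethyl both have 7 heavy atoms, this replacement at the saturated ring carbon gives a 60-fold higher number from compound 1 to compound 3 (1.78 log units; beyond the scatter). The two saturated groups also differ clearly, with an 8.5-fold higher number from compound 2 to compound 3 (0.93 log units; beyond the scatter), so a saturated ring at this position does not by itself fix the number. No measurement given here accounts for these differences. The compounds shown leave open whether ring size or the methylene link in cyclohexylmethyl matters more. Directly attached cyclohexyl, benzyl and an open chain such as n-butyl also remain open at this carbon.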